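The source may report more compounds than this note shows. Statements on the series, on what has been measured and on what is new or still open speak of the compounds shown alone.

Three compounds of this series carry a number in a functional assay on NCI-H226 cells (Homo sapiens) for inhibition, read by MTT assay, with a stated time of 48 h, tested at 10 uM; on this read-out lower numbers stand for less inhibition and higher numbers for more inhibition at the one concentration tested (going by the name of the read-out). Compound 1 `Cc1cc(F)cc(Nc2cc(NC(=O)Nc3c(Cl)cccc3Cl)ncn2)c1` gives 78.1%. Compound 3 `COc1ccc(OC)c(Nc2cc(NC(=O)Nc3c(Cl)cccc3Cl)ncn2)c1` gives 81.7%. Compound 2 `COc1cc(NC(=O)Nc2cc(Nc3cccc(C(C)(C)C)c3)ncn2)cc(OC)c1` gives 40%, the lowest of the three; its gap to compound 1 and its gap to compound 3 both lie beyond the scatter, so compound 2 stands clearly apart at the low end. Compound 1 and compound 3 lie within the scatter of each other, and no order between them can be read.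

Compound 4 `COc1cc(NC(=O)Nc2cc(Nc3ccc(OC)c(I)c3)ncn2)cc(OC)c1` has not yet been measured in this assay. It differs from compound 2 in one place: 3-iodo-4-methoxyphenyl in place of 3-(tert-butyl)phenyl on a nitrogen on an aromatic ring. Everything else in compound 2 is kept in compound 4, and no pair of measured compounds separates the part kept from the part exchanged, so how much of the low number of compound 2 rests on the 3-(tert-butyl)phenyl is not known. A step of moderate size upward is expected, with wide uncertainty, and an outcome with no step beyond the scatter is not excluded. Compound 4 is estimated at 52%, with a range from 25% to 78%. The step this estimate expects is a number 12 percentage points higher from compound 2 to compound 4 (beyond the scatter).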

Compound 4, a percentage reported as inhibition, at one concentration (the size of the read-out at that concentration, not a potency): 40.1%
Beside the measured number, compound 4's estimate is 11.9 percentage points above it; measured number inside the range.
By their numbers in this assay, from the lowest: compounds 2 and 4 (each within the scatter of the next); then compounds 1 and 3 (each within the scatter of the next).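

In this assay, among the compounds shown here, exchanging 3-(tert-butyl)phenyl for 3-iodo-4-methoxyphenyl on a nitrogen on an aromatic ring gives a number 0.1 percentage points higher from compound 2 to compound 4 (within the scatter), the first direct reading of a change at this position, and it shows no step beyond the scatter. A group of carbon only gives way to one carrying oxygen and iodine, and the read-out at the one concentration tested does not follow the exchange, so the low number of compound 2 does not rest on 3-(tert-butyl)phenyl as such, at least not in a way this exchange undoes. Nothing measured here bears on why these two groups read alike.

This single pair cannot tell whether the position is insensitive in general or whether these two groups merely happen to coincide, and how much of the shared low level rests on the part kept in compound 2 and compound 4 stays unresolved without a pair that changes that part alone. Going by these compounds, it also remains open whether a quite different group on the same nitrogen, such as an aminophenyl or a carboxyphenyl ring, would move the number beyond the scatter.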